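This account rests on a few compounds, and the source may have more. Where it says the series, first, only, none or still open, it means among the compounds named here.

In a functional assay on LNCaP cells (Homo sapiens) for cytotoxicity, read by MTT assay, with a stated time of 24 h (on this read-out lower numbers stand for an effect already at smaller amounts and higher numbers for an effect only at larger amounts of compound), compound 1 `Fc1ccc(N2CCN(CCN3CCN(c4ccc(F)cc4)CC3)CC2)cc1` gives 71200 nM and stands level with its two measured relatives, since compound 2 `O=[N+]([O-])c1cc(C(F)(F)F)ccc1N1CCN(CCN2CCN(c3ccc(C(F)(F)F)cc3[N+](=O)[O-])CC2)CC1` gives 63200 nM and compound 3 `O=[N+]([O-])c1ccc(N2CCN(CCCN3CCN(c4ccc([N+](=O)[O-])cc4C(F)(F)F)CC3)CC2)c(C(F)(F)F)c1` gives 55500 nM within the usual scatter. Compound 4 `O=[N+]([O-])c1ccc(N2CCN(CCN3CCN(c4ccc(F)cc4)CC3)CC2)cc1` keeps the core of compound 1 but has nitro in place of fluoro on an aromatic carbon. No measured pair differs in just one place, so the size of this step in this assay is not shown directly. Compound 3 also carries nitro groups and at 55500 nM sits level with compound 1, so no step beyond the scatter is expected. The expected 1.2-fold lower number from compound 1 to compound 4 (0.07 log units; within the scatter) is therefore small. The estimate for compound 4 is 60000 nM (expected range 28000 nM to 110000 nM).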

Compound 4, half-maximal effective concentration: 77900 nM
Estimate against measurement, compound 4: 1.3-fold (0.11 log units) below; low and high end bracket the measured number.
By their numbers in this assay, from the lowest: compounds 3, 2, 1 and 4 (each within the scatter of the next).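

Among these compounds, the first direct reading at this position comes from replacing fluoro with nitro, para to a large group: in this assay this gives a 1.1-fold higher number from compound 1 to compound 4 (0.04 log units; within the scatter). A single fluorine atom thus gives way to a larger group with two hydrogen-bond acceptors, and the number stays level with that of compound 1. No supporting measurement offers an explanation for this result. On these data alone, whether an amine or a carboxylic acid at this position would also leave the number level remains open. So does the effect of changing the fluoro on the other aromatic ring of compound 4.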